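The source may report more compounds than this note shows. Statements on the series, on what has been measured and on what is new or still open speak of the compounds shown alone.

Measured compounds:
- compound 1 `[O-][n+]1ccc(Cl)c(Oc2ccccc2)c1`: > 300 mg/kg
- compound 2 `COc1ccc(Oc2c[n+]([O-])ccc2C)cc1`: 300 mg/kg

In a functional assay on the whole organism with Mus musculus as the target, in the maximal electroshock model, with a stated time of 30 min (on this read-out higher numbers stand for an effect only at larger amounts of compound and lower numbers for an effect already at smaller amounts), compound 1 gives only a limit, > 300 mg/kg, so its position on the numbers is not fixed; the limit of > 300 mg/kg in this assay, at which 1 of the 2 values shown sits, marks that limit. Compound 2, a different structure, gives 300 mg/kg in this assay.

Compound 3 `CC(C)(C)c1cc[n+]([O-])cc1Oc1ccccc1` differs from compound 1 by tert-butyl in place of chloro on an aromatic carbon.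

Within the data shown here, no measured pair shows what this change does here, so the step of a number no higher from compound 1 to compound 3 (the limit leaves the size open) is expected to be small or none beyond the scatter. Compound 3 is therefore estimated at 300 mg/kg in this assay, within a range from 100 mg/kg to 600 mg/kg.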

Compound 3, minimum effective dose: 30 mg/kg
The estimate for compound 3 lay 10-fold (1.00 log units) above the measured number; measured number below the stated range.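

Among these compounds, on the aromatic carbon opposite the ring nitrogen, tert-butyl in place of chloro gives an at least 10-fold lower number from compound 1 to compound 3 (1.00 log units; beyond the scatter) and is the only step that can be read here. This place on the shared core therefore matters: with tert-butyl, an effect already appears at a smaller amount of compound. From the compounds shown here alone, the number for compound 1 is a limit, so the full size of the step stays open: the limit of > 300 mg/kg in this assay, at which 1 of the 3 values shown sits.

Going by these compounds, it remains open whether an ethyl or cyclohexyl group would do the same as tert-butyl. An amine or a carboxylic acid at this place is also untested by the compounds shown.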